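The source may hold more compounds than are shown below. What is called first, only, known or untested is meant among the compounds shown, and "the series" means these compounds.

Measured so far:
- compound 1, `Cc1nnc(C[S+]([O-])C(c2ccccc2)c2ccccc2)s1`: "not active" (no number reported)
- compound 2, `Cc1noc(C[S+]([O-])C(c2ccccc2)c2ccccc2)n1`: 56700 nM
- compound 3, `[O-][S+](Cc1csc(Br)c1)C(c1ccccc1)c1ccccc1`: 16600 nM

Notes on the series. All three share the same core; they differ only in the aromatic group on the saturated chain carbon bound to a sulfur. In an assay on HEK293 cells for inhibition of sodium-dependent dopamine transporter (Homo sapiens), read by scintillation counting, with stated times of 5 min and 1 min (on this read-out higher numbers stand for weaker inhibition and lower numbers for stronger inhibition), compound 1 gives "not active" (no number reported), a report without a number. In this assay compound 2 gives 56700 nM and compound 3 gives 16600 nM. Among the measured compounds shown here, compound 3 thus has the lowest of the two numbers; the only step available, a 3.4-fold lower number from compound 2 to compound 3 (0.53 log units; beyond the scatter), shows that swapping one five-membered heteroaromatic group for another moves the number modestly.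

Compound 4 is `[O-][S+](Cc1ccncc1)C(c1ccccc1)c1ccccc1`. Its change from compound 3: pyridin-4-yl in place of 5-bromothiophen-3-yl on a saturated chain carbon bound to a sulfur. For the measured compounds named here, no measured step covers a six-membered ring here, so the one step from compound 2 to compound 3 is only a loose guide to the size such swaps produce. Compound 4 is expected to land somewhat weaker than compound 3, with a 2.1-fold higher number from compound 3 to compound 4 (0.32 log units; beyond the scatter) as the estimated step. The estimate for compound 4 in this assay is 35000 nM, with a range from 10000 nM to 120000 nM.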

Compound 4, half-maximal inhibitory concentration: 63500 nM
Estimate against measurement, compound 4: 1.8-fold (0.26 log units) below, and the stated range covers the measured number.
By their numbers in this assay, from the lowest: compound 3; then compounds 2 and 4 (each within the scatter of the next).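

In this assay, a six-membered aromatic ring now occupies the position on a saturated chain carbon bound to a sulfur, and pyridin-4-yl in place of 5-bromothiophen-3-yl gives a 3.8-fold higher number from compound 3 to compound 4 (0.58 log units; beyond the scatter) and so lies beyond the scatter. Pyridin-4-yl in place of 3-methyl-1,2,4-oxadiazol-5-yl gives a 1.1-fold higher number from compound 2 to compound 4 (0.05 log units; within the scatter) and so lies within the scatter, which leaves compound 3 as the only numbered compound set apart from both others. No data in hand bear on what lies behind this result.

Open, going by these compounds, is whether the separation of compound 3 follows the bromine or the thiophene ring, which a thiophen-3-yl group without bromine and a 4-bromophenyl group would help to separate. Also open, on these data alone, is how pyridin-3-yl or pyridin-2-yl would compare with pyridin-4-yl at this position.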